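Adding an Ethoxy Group to Compound 1

A few compounds are considered here, and "the series" means these few. Any claim that something is new, unique, unknown or untested is made for them only; others in the source may bear on it.

Compound 1 `Cc1ccc2c(c1)C(=O)/C(=C/c1ccccc1)CN2CC(=O)O`: 4.23%
Compound 2 `Cc1cccc2c1N(CC(=O)O)C/C(=C\c1cccc(O)c1)C2=O`: 75.6%
Compound 3 `Cc1cccc(/C=C2\CN(CC(=O)O)c3c(C)cccc3C2=O)c1`: 39.1%

In an assay on HL-60 cells for inhibition of glutathione S-transferase P (Homo sapiens), read by spectrophotometry, tested at 20 uM (a lower number here means less inhibition, a higher number more inhibition at the concentration tested (going by the name of the read-out)), compound 1 gives 4.23%, the lowest of the three numbers; compound 3 stands clearly higher, and compound 2 higher still. Compound 4 `CCOc1ccc(/C=C2\CN(CC(=O)O)c3ccc(C)cc3C2=O)cc1` differs from compound 1 by ethoxy in place of hydrogen on an aromatic carbon. Within the data shown here, the only measured step that alters the same pendant ring is a number 36.5 percentage points lower from compound 2 to compound 3 (beyond the scatter), but there a hydroxy was traded for a methyl rather than a hydrogen for an ethoxy, so it bears on the new change only loosely. Among the measured compounds shown here, no measured step adds an ethoxy anywhere. With so little to lean on, only a modest rise from the low starting point of compound 1 is expected, a number 10.8 percentage points higher from compound 1 to compound 4 (beyond the scatter). Compound 4 is therefore estimated at 15%, between 0% and 40%.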

Compound 4, a percentage reported as inhibition, at one concentration (the size of the read-out at that concentration, not a potency): 25.8%
For compound 4 the middle estimate is 10.8 percentage points below the measured one; the range from low to high includes it.
By their numbers in this assay, from the lowest: compound 1; then compound 4; then compound 3; then compound 2.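

Putting ethoxy in place of hydrogen on this aromatic carbon, para to a large group, gives in this assay a number 21.6 percentage points higher from compound 1 to compound 4 (beyond the scatter). This shows that the position can carry a group larger than hydrogen without losing inhibition, and that here the number rises. Nothing at hand explains the rise.

Going by these compounds, whether a shorter methoxy, a longer butoxy chain or an amine at this carbon would raise or lower the number remains open. So does whether ethoxy would have the same effect on the core of compound 2 or compound 3.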